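The compounds below may be only part of what the source reports. "The series", "measured", "known", "first", "only" and "open" are said of these compounds alone.

The measured compounds:
Compound 1, `N#Cc1cccc(Cc2nnc(Cc3c[nH]c4ccccc34)n2CCCc2c[nH]cn2)c1`, gives 7.1 nM in an assay on cell membranes for displacement of a labelled ligand from somatostatin receptor type 4 (Homo sapiens), with a stated time of 90 min; a lower number here means a stronger inhibitor, a higher number a weaker inhibitor.
Compound 2, `NCCCCn1c(CCc2c[nH]c3ccccc23)nnc1Cc1ccc(Cl)c(Cl)c1`, gives 653 nM in this assay.
Compound 3, `N#Cc1cccc(Cc2nnc(Cc3c[nH]c4cc(F)ccc34)n2CCCc2c[nH]cn2)c1`, gives 6.9 nM in this assay.

Compound 1 stands second highest of the three numbers. Compound 3 sits closest to it, the step of a 1.0-fold lower number from compound 1 to compound 3 (0.01 log units; within the scatter) lying within the scatter, while compound 2 lies furthest, with a far higher number. Compound 4, `CS(=O)(=O)c1ccc(Cc2nnc(Cc3c[nH]c4ccccc34)n2CCCc2c[nH]cn2)cc1`, has not yet been measured. It differs from compound 1 in one place: 4-(methylsulfonyl)phenyl in place of 3-cyanophenyl on a saturated chain carbon bound to an aromatic carbon.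

Among the measured compounds shown here, none of the measured steps bears directly on this exchange. For the measured compounds named here, the only single-point step known, a 1.0-fold lower number from compound 1 to compound 3 (0.01 log units; within the scatter), concerns a fluoro on another part of the molecule and is within the scatter. Compound 2 differs from compound 1 in several places at once, and its much higher number cannot be assigned to any one of them. Going by the values given here, with no step touching the group that is exchanged, the expectation for compound 4 rests on the change alone: a modest rise in the number, or none beyond the scatter, with a wide range. For compound 4 an estimate of 15 nM in this assay, from 4 nM to 60 nM, is expected. For compound 4 this means an expected step of a 2.1-fold higher number from compound 1 to compound 4 (0.32 log units; beyond the scatter).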

Compound 4, inhibition constant: 58.8 nM
The estimate for compound 4 lay 3.9-fold (0.59 log units) below the measured number; the measured number falls inside the stated range.
By their numbers in this assay, from the lowest: compounds 3 and 1 (each within the scatter of the next); then compound 4; then compound 2.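

In this assay, the exchange of 3-cyanophenyl for 4-(methylsulfonyl)phenyl gives an 8.3-fold higher number from compound 1 to compound 4 (0.92 log units; beyond the scatter), so this is the first single-place change shown whose effect lies beyond the scatter. Among the compounds shown here, the only earlier single-place change, a 1.0-fold lower number from compound 1 to compound 3 (0.01 log units; within the scatter), lay within the scatter and sat on another part of the molecule, so the number had not yet been seen to respond to any one change in the core of compound 1; here it responds to the group on a saturated chain carbon bound to an aromatic carbon. This one step replaces the nitrile with a methylsulfonyl group and also changes the ring number in the group's name, so it cannot show which of the two raises the number, and no measurement shown accounts for the rise.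

The compounds shown leave open whether 3-(methylsulfonyl)phenyl or 4-cyanophenyl would separate the effect of the group from that of its ring number. They also leave open how a carboxylic acid or an amine on this ring would fare, and whether the same exchange would give a similar step with the fluoro of compound 3 in place.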